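A few compounds are considered here, and "the series" means these few. Any claim that something is new, unique, unknown or untested is made for them only; others in the source may bear on it.

Compound 1 `Nc1ccccc1NC(=O)CCCNCC(=O)Nc1ccc(Br)cc1`: 55500 nM
Compound 2 `Nc1ccccc1NC(=O)CCCNCC(=O)Nc1cccc([N+](=O)[O-])c1`: 22500 nM

In a functional assay on HCT-116 cells (Homo sapiens) for inhibition, read by MTT assay, with a stated time of 2 days (a higher number here means a weaker inhibitor of growth, a lower number a stronger inhibitor of growth), compound 2 has the lower of the two numbers, 22500 nM. Compound 3 `Nc1ccccc1NC(=O)CCCNCC(=O)Nc1ccccc1Cl` has 2-chlorophenyl in place of 3-nitrophenyl on an amide-type nitrogen. Within the data shown here, only one measured step bears on this place, and it is modest: a 2.5-fold lower number from compound 1 to compound 2 (0.39 log units; beyond the scatter). One step sets no rule, but compound 1, which also carries a halogen, gives 55500 nM, so a modest rise is expected rather than a large change. The expected step is a 1.6-fold higher number from compound 2 to compound 3 (0.19 log units; within the scatter). For compound 3 the estimated value is 35000 nM, with an expected range of 15000 nM to 80000 nM.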

Compound 3, concentration for total growth inhibition: > 100000 nM
Compound 3 was reported as a limit (the forecaster's own chance of this, stated with the estimate: 5%); at least 2.8-fold (0.45 log units) between middle value and limit.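

The group on the amide-type nitrogen can shift growth inhibition further than the earlier step suggested: in this assay, 2-chlorophenyl in place of 3-nitrophenyl gives an at least 4.4-fold higher number from compound 2 to compound 3 (0.64 log units; beyond the scatter). With 2-chlorophenyl in place of 4-bromophenyl, the result is an at least 1.8-fold higher number from compound 1 to compound 3 (0.25 log units; that floor lies within the scatter), so no firm order can be set for this pair. Compound 3 is reported only as a limit: the limit of > 100000 nM in this assay, at which 1 of the 3 values shown sits.

The compounds shown do not separate the identity of the halogen from its place on the ring. Going by these compounds, what a plain phenyl group, or a phenyl ring carrying a carboxylic acid, would give remains open.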